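Amino for Methoxy on the Core of Compound 3

A few compounds are considered here, and "the series" means these few. Any claim that something is new, unique, unknown or untested is made for them only; others in the source may bear on it.

Measured compounds:
compound 1 `COc1ccc(-c2cc3ccccc3c(-c3cccc(OC)c3)n2)cc1`: 860 nM
compound 2 `COc1ccc(-c2cc3ccccc3c(-c3cccc(N)c3)n2)cc1`: 950 nM
compound 3 `COc1cc(OC)cc(-c2cc3ccccc3c(-c3cccc(OC)c3)n2)c1`: 1120 nM

All three were tested in a functional assay on T47D cells (Homo sapiens) for cytotoxicity, read by CCK-8 assay and cell counting, with a stated time of 72 h; on this read-out higher numbers stand for weaker inhibition and lower numbers for stronger inhibition. Compound 2 differs from compound 1 by amino in place of methoxy on an aromatic carbon, and this change gave a 1.1-fold higher number from compound 1 to compound 2 (0.04 log units; within the scatter). How the core of compound 3 differs from the core of compound 1 is not broken down here; their values lie within the scatter of each other. Compound 4 `COc1cc(OC)cc(-c2cc3ccccc3c(-c3cccc(N)c3)n2)c1` has not yet been measured; it differs from compound 3 by amino in place of methoxy on an aromatic carbon, the same change at the same place as before. In this assay a step of a 1.1-fold higher number from compound 3 to compound 4 (0.03 log units; within the scatter) is expected, because the same change gave a 1.1-fold higher number from compound 1 to compound 2 (0.04 log units; within the scatter) in the earlier pair. Compound 4 is therefore estimated at 1200 nM, with a likely range from 600 nM to 2400 nM.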

Compound 4, half-maximal inhibitory concentration: 980 nM
The estimate for compound 4 lay 1.2-fold (0.09 log units) above the measured number, within the range that was stated.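

In this assay, putting amino in place of methoxy on the core of compound 3 gave a 1.1-fold lower number from compound 3 to compound 4 (0.06 log units; within the scatter) and so no readable change. Set beside the earlier pair, the two steps agree: the same change on two cores in this assay, a 1.1-fold higher number (0.04 log units; within the scatter) from compound 1 to compound 2 and a 1.1-fold lower number (0.06 log units; within the scatter) from compound 3 to compound 4, 1.3-fold (0.10 log units) apart, within the scatter of two such steps. On both cores, then, going from 3-methoxyphenyl to 3-aminophenyl left the number where the scatter cannot separate it, but this does not show that the change strengthens or weakens inhibition on either core, and two cores cannot speak for others.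

The compounds shown leave open whether another group at this place, such as a hydroxyl, a carboxylic acid or a longer alkoxy chain, would move the number beyond the scatter.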